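A few compounds are considered here, and "the series" means these few. Any claim that something is new, unique, unknown or untested is made for them only; others in the source may bear on it.

Compound 1 `COc1ccc(C2=NN(C3=NC(=O)/C(=C4\C(=O)Nc5ccc(Br)cc54)S3)C(c3ccc(Cl)cc3)C2)cc1` — 190 nM
Compound 2 `COc1ccc(C2=NN(C3=NC(=O)/C(=C4\C(=O)Nc5ccc(Cl)cc54)S3)C(c3ccc(Cl)cc3)C2)cc1` — 270 nM
Compound 3 `COc1ccc(-c2cc(-c3ccc(Cl)cc3)n(C3C(=O)Nc4ccc(Br)cc43)n2)cc1` — 12400 nM

All three values come from a functional assay on cells (Leukemia cell, Homo sapiens) for cytotoxicity, read by sulforhodamine B assay, with a stated time of 48 h; on this read-out higher numbers stand for weaker inhibition of growth and lower numbers for stronger inhibition of growth. Compounds 1 and 2 share one core and differ in a single place: chloro in place of bromo on an aromatic carbon. The step of a 1.4-fold higher number from compound 1 to compound 2 (0.15 log units; within the scatter). Compound 3 is built on a different core; the difference between the two cores is not broken down here. Compound 3 stands apart from both other compounds, its number lying beyond the scatter above those of compound 2 and compound 1.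

Compound 4 `COc1ccc(-c2cc(-c3ccc(Cl)cc3)n(C3C(=O)Nc4ccc(Cl)cc43)n2)cc1` has not yet been measured. It relates to compound 3 as compound 2 relates to compound 1: chloro in place of bromo on an aromatic carbon. The place of the change is described in the same words for both pairs, so this is the same change carried onto the second core. For the measured compounds named here, because a 1.4-fold higher number from compound 1 to compound 2 (0.15 log units; within the scatter) lies within the scatter, the same change on the core of compound 3 is expected to shift the number only a little, although no second example on that core is available. Compound 4 is expected to give 15000 nM, with a likely range from 6000 nM to 40000 nM. That estimate means a 1.2-fold higher number from compound 3 to compound 4 (0.08 log units; within the scatter).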

Compound 4, concentration for 50% growth inhibition: 28000 nM
Compound 4: the middle estimate sits 1.9-fold (0.27 log units) below what was measured; low and high end bracket the measured number.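

In this assay, chloro in place of bromo on the core of compound 3 gives a modest step that lies just beyond the scatter (a 2.3-fold higher number from compound 3 to compound 4 (0.35 log units; beyond the scatter)). On the core of compound 1 the same change stays within the scatter, yet the two steps cannot be told apart, so in these two pairs the change carries from one core to the other without a detectable difference: the same change on two cores in this assay, a 1.4-fold higher number (0.15 log units; within the scatter) from compound 1 to compound 2 and a 2.3-fold higher number (0.35 log units; beyond the scatter) from compound 3 to compound 4, 1.6-fold (0.20 log units) apart, within the scatter of two such steps. This rests on a single pair per core and a single exchange of halogens, so it does not show that the two cores always respond alike, nor that any other change would carry over in the same way.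

Only bromo and chloro appear at this place, which leaves open how fluoro, a nitrile or an amine there would read on either core. Also open, going by these compounds, is what a carboxylic acid or a longer chain in place of the methoxy group would do, and whether such a change would carry between the cores as this one does.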